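The source may report more compounds than this note shows. Statements on the series, on what has been measured and on what is new or still open speak of the compounds shown alone.

Measured compounds:
compound 1, `CC(C)NC(=O)[C@H]1CC[C@@H](n2/c(=N/C(=O)c3ccc(F)c(F)c3)[nH]c3ccc(CN4CCC(C(C)(C)O)CC4)cc32)CC1`, with 19 mL.min-1.g-1
compound 2, `CCOC(=O)[C@H]1CC[C@@H](n2/c(=N/C(=O)c3ccccc3)[nH]c3ccc(CN4CCCCC4)cc32)CC1`, with 706 mL.min-1.g-1

Both compounds were run in an in vitro ADME assay on microsomes from liver (Rattus norvegicus) for metabolic stability; on this read-out lower numbers stand for slow clearance and higher numbers for fast clearance. Compound 1 gives 19 mL.min-1.g-1, the lowest of the two numbers. Compound 2 gives 706 mL.min-1.g-1, a much higher number, and the gap between the two lies beyond the usual scatter. The two structures differ in several places at once, so no single change can be tied to that gap.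

Compound 3, `CC(C)NC(=O)[C@H]1CC[C@@H](n2/c(=N/C(=O)c3cccc(C#N)c3)[nH]c3ccc(CN4CCC(C(C)(C)O)CC4)cc32)CC1`, has not yet been measured. It differs from compound 1 in one place only: 3-cyanophenyl in place of 3,4-difluorophenyl on a carbonyl carbon. Everything else in the shared core of compound 1 is kept, including the groups that set compound 1 apart from compound 2.

Because compound 1 gives 19 mL.min-1.g-1 and the change from compound 1 to compound 3 is confined to a ring on a carbonyl carbon, only a small step is expected in this assay, if any, with a slight lean towards a higher number. The step from compound 1 to compound 3 is estimated as a 1.3-fold higher number from compound 1 to compound 3 (0.12 log units; within the scatter). Compound 3 is expected to give 25 mL.min-1.g-1, with a likely range from 10 mL.min-1.g-1 to 60 mL.min-1.g-1.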

Compound 3, intrinsic clearance in microsomes: 17 mL.min-1.g-1
The estimate for compound 3 lay 1.5-fold (0.17 log units) above the measured number; low and high end bracket the measured number.
By their numbers in this assay, from the lowest: compounds 3 and 1 (each within the scatter of the next); then compound 2.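

In this assay the exchange of 3,4-difluorophenyl for 3-cyanophenyl on a carbonyl carbon gives a 1.1-fold lower number from compound 1 to compound 3 (0.05 log units; within the scatter) and so leaves the two compounds indistinguishable on this read-out. This is the only comparison shown that changes a single place, since compound 1 and compound 2 differ in several places at once and their gap cannot be tied to any one of them. Here two fluorine atoms leave and a nitrile enters while the ring itself and the rest of the shared core are kept, and this particular swap opens no measurable gap in this assay, although nothing measured here explains that result.

One swap cannot show whether other groups on this carbonyl carbon would behave the same way, for example a ring bearing an amine or a carboxylic acid, or a saturated cyclohexyl ring in place of the aromatic one. It also remains open which of the places that separate compound 1 from compound 2 accounts for their large gap, as no single-place step connects those two compounds.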